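Swapping an ester for an extended benzamide

The source may hold more compounds than are shown below. What is called first, only, known or untested is meant among the compounds shown, and "the series" means these compounds.

Compound 1 `N#CN/C(=N\CCOC(=O)c1ccccc1)NCCCOc1cccc(CN2CCCCC2)c1` gives 7.64 in a functional assay on cardiac atrium for antagonist activity at histamine H2 receptor (Cavia porcellus); a lower number here means a less potent compound, a higher number a more potent compound, by a factor of ten per unit of this negative logarithm.
Compound 2 `N#CN/C(=N\CCNC(=O)c1ccccc1[N+](=O)[O-])NCCCCOc1cccc(CN2CCCCC2)c1` gives 7.52 in this assay.

Compound 1 holds the higher of these two numbers, but compound 2 sits only a little lower, and that gap lies within the usual scatter of this assay. Compound 3 `N#CN/C(=N\CCCCNC(=O)c1ccccc1)NCCCOc1cccc(CN2CCCCC2)c1` has not been measured yet. It differs from compound 1 by 2-benzamidoethyl in place of benzoyloxy on a saturated chain carbon, two bonds along the chain from a double-bonded nitrogen. Within the data shown here, no step between measured compounds is known, so the expectation rests on the two values alone. For compound 3 the step of a number 0.14 log units lower from compound 1 to compound 3 (within the scatter) is expected to be small, with no direction beyond the scatter. Compound 3 is therefore estimated at 7.5, within 6.9 to 8.1.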

Compound 3, negative logarithm of the antagonist equilibrium constant: 6.81
Compound 3: the middle estimate sits 0.69 log units above what was measured, and the stated range ends above it.
By their numbers in this assay, from the lowest: compound 3; then compounds 2 and 1 (each within the scatter of the next).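

At this position on the chain, the group is not freely exchangeable: putting 2-benzamidoethyl in place of benzoyloxy gives a number 0.83 log units lower from compound 1 to compound 3 (beyond the scatter) in this assay. This change replaces the ester with an amide and also lengthens the chain, so a single step cannot assign the drop to either one. No available evidence bears on the reason for this step.

The compounds shown leave open which of the two changes matters. Benzamido, which keeps the shorter chain, and 2-benzoyloxyethyl, which keeps the ester on the longer chain, would separate them.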